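Sulfonyl-side variation in a shared sulfonamide series

This account rests on a few compounds, and the source may have more. Where it says the series, first, only, none or still open, it means among the compounds named here.

In an ADME assay on HEK293 cells (Homo sapiens) for cytotoxicity, read by resazurin assay, with a stated time of 48 h (on this read-out higher numbers stand for lower toxicity in this test and lower numbers for higher toxicity in this test), compound 1 `O=S(=O)(Nc1ccc2oc(-c3ccccc3)nc2c1)c1ccccc1O` gives 33000 nM, compound 3 `O=S(=O)(Nc1ccc2oc(-c3ccccc3)nc2c1)c1ccccc1C(F)(F)F` gives 80000 nM and compound 2 `COc1ccc(Cl)cc1S(=O)(=O)Nc1ccc(-c2nc3ccccc3o2)cc1` gives 75000 nM. Compound 2 holds the second highest of the three numbers; the gap to compound 3 lies within the scatter, while compound 1 sits beyond it with the lower number. Going by the values given here, the one measured step, a 2.4-fold higher number from compound 1 to compound 3 (0.38 log units; beyond the scatter), concerns a substituent on the group attached to the sulfonyl sulfur and was modest. Compound 4 `O=S(=O)(Nc1ccc(-c2nc3ccccc3o2)cc1)c1ccc(Cl)s1` differs from compound 2 as 5-chlorothiophen-2-yl in place of 5-chloro-2-methoxyphenyl on a sulfonyl sulfur. Among the compounds with values here, no measured step exchanges this whole group, so the nearest guide is the modest size of the step from compound 1 to compound 3. For compound 4 the step of a 1.3-fold lower number from compound 2 to compound 4 (0.10 log units; within the scatter) is expected to stay within the scatter, giving an estimated 60000 nM with range 25000 nM to 150000 nM.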

Compound 4, half-maximal cytotoxic concentration: > 100000 nM
Compound 4: no number, only a limit; the forecaster's own chance of this, stated with the estimate: 15%; middle value at least 1.6-fold (0.22 log units) from the limit.
By their numbers in this assay, from the lowest: compound 1; then compounds 2 and 3 (each within the scatter of the next). At a limit, above all of these: compound 4.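

Going by these compounds alone, exchanging the whole group on the sulfonyl sulfur gives an at least 1.3-fold higher number from compound 2 to compound 4 (0.12 log units; that floor lies within the scatter), a first reading at this position for a five-membered aromatic ring with a hetero atom. That ring brings no lower number in this assay, whereas the earlier step changed only one substituent. Compound 4 reads only as a limit, not a number: the limit of > 100000 nM in this assay, at which 1 of the 4 values shown sits.

Going by these compounds, how far compound 4 lies past that limit stays open, and with it whether this step exceeds the scatter. Also open, on these data alone, is what an amine or a carboxylic acid in place of the chlorine of 5-chlorothiophen-2-yl would give.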